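Methyl to methoxy on the benzyl arm of compound 2

The source may hold more compounds than are shown below. What is called first, only, known or untested is meant among the compounds shown, and "the series" means these compounds.

Measured in an in vitro functional assay on cells for agonist activity at Bombesin receptor subtype-3 (Homo sapiens), read by luminescence and calcium flux; a lower number here means that less compound is needed, a higher number that more compound is needed for the effect:
compound 1 `CCCCc1cnc(C(CCCO)Cc2ccc(-c3ccccc3C(=O)O)cc2)[nH]1`: 1900 nM
compound 2 `Cc1cccc(Cc2cnc(CCc3ccc(-c4ccccc4C(=O)O)cc3)[nH]2)c1`: 4310 nM
compound 3 `CCCCc1cnc(C(Cc2ccc(-c3ccccc3C(=O)O)cc2)C(C)C)[nH]1`: 4620 nM

In this assay compound 2 stands second highest of the three numbers; its gap to compound 3 lies within the scatter, while compound 1 sits at a lower number beyond it. Compound 4 `COc1cccc(Cc2cnc(CCc3ccc(-c4ccccc4C(=O)O)cc3)[nH]2)c1` differs from compound 2 by methoxy in place of methyl on an aromatic carbon. Among the measured compounds shown here, the only step between measured compounds, a 2.4-fold higher number from compound 1 to compound 3 (0.39 log units; beyond the scatter), concerns the saturated chain carbon and does not bear on this change; no measured pair varies the group on the six-membered ring. With nothing to lean on, no step beyond the scatter is expected in this assay in either direction. Compound 4 is therefore estimated at 4300 nM, within 2000 nM to 9000 nM. The estimate means a 1.0-fold lower number from compound 2 to compound 4 (0.00 log units; within the scatter), expected to stay within the scatter.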

Compound 4, half-maximal effective concentration: 4120 nM
For compound 4 the middle estimate is 1.0-fold (0.02 log units) above the measured one; measured number inside the range.
By their numbers in this assay, from the lowest: compound 1; then compounds 4, 2 and 3 (each within the scatter of the next).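

In this assay the position on the benzyl arm gets its first direct reading: a 1.0-fold lower number from compound 2 to compound 4 (0.02 log units; within the scatter), so 3-methylbenzyl and 3-methoxybenzyl read alike here. At this position, the extra heavy atom and the hydrogen-bond acceptor that enter with methoxy bring no step beyond the scatter. No available evidence bears on this result. As far as these compounds go, whether the position stays this flat with an amine or a carboxylic acid on the aromatic carbon remains open. A longer chain in place of methoxy is equally unresolved.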